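The source may hold more compounds than are shown below. What is called first, only, known or untested is meant among the compounds shown, and "the series" means these compounds.

Measured compounds:
- compound 1 `CCCNc1nc(N)c(C(=O)N=C(N)N)nc1Cl` — 24%
- compound 2 `NC(N)=NC(=O)c1nc(Cl)c(NC2CC2)nc1N` — "not determined" (no result reported)
- compound 3 `CSc1nc(N)c(C(=O)N=C(N)N)nc1Cl` — 12%

Within the data shown here, in an assay for inhibition of acid-sensing ion channel 3 (Homo sapiens), read by patch clamp, tested at 1 uM (on this read-out lower numbers stand for less inhibition and higher numbers for more inhibition at the one concentration tested (going by the name of the read-out)), compound 3 gives the lowest of the two numbers available; its nearest neighbour is compound 1, and the only single-point step recorded, a number 12 percentage points lower from compound 1 to compound 3 (beyond the scatter), joins these two. For compound 2 no result was reported.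

Compound 4 `NC(N)=NC(=O)c1nc(Cl)c(Sc2ccccc2)nc1N` is the next compound to be measured. Among the measured compounds shown here, the only difference from compound 3 is phenyl in place of methyl on a sulfur. For the measured compounds named here, no measured step in this set changes a group on the sulfur; the one step known, from propylamino to methylsulfanyl on the aromatic carbon, alters a different kind of group and so offers no direct guide. Given that compound 3 stands at 12%, the expected position for compound 4 in this assay is uncertain, and the estimated step of a number 10 percentage points higher from compound 3 to compound 4 (within the scatter) is taken as small, with a wide margin either way. Compound 4 is therefore expected to give about 22%, most likely between 2% and 55%.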

Compound 4, a percentage reported as inhibition, at one concentration (the size of the read-out at that concentration, not a potency): 11%
Compound 4: middle estimate off by 11 percentage points, on the high side, within the range that was stated.
By their numbers in this assay, from the lowest: compounds 4 and 3 (each within the scatter of the next); then compound 1.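

In this assay, phenyl in place of methyl on the sulfur gives a number 1 percentage points lower from compound 3 to compound 4 (within the scatter), so a group of one carbon and a six-membered aromatic ring cannot be told apart at this sulfur. Phenylsulfanyl in place of propylamino on the aromatic carbon gives a number 13 percentage points lower from compound 1 to compound 4 (beyond the scatter), and methylsulfanyl gave a number 12 percentage points lower from compound 1 to compound 3 (beyond the scatter), so now both sulfur groups shown stand apart from the propylamino group of compound 1. No measurement here explains why the group on the sulfur makes so little difference.

From the compounds shown here alone, whether a longer chain such as hexyl or a benzyl group on the sulfur would also leave the result unmoved remains open. So does whether an oxygen in place of that sulfur, carrying the same phenyl, would behave like compound 4.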